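The compounds below may be only part of what the source reports. "The series", "measured", "known", "first", "only" and "open" are said of these compounds alone.

All four compounds share one core, a piperidine amide carrying a cyclopropyl sulfonamide with a trifluoromethyl-substituted aryl group; they differ only in the aromatic ring attached to the carbonyl carbon. Compound 1 `O=C(c1ccccc1)N1CCC(N(C2CC2)S(=O)(=O)c2cccc(C(F)(F)F)c2)CC1` was run in an assay on cells for inhibition of Voltage-dependent L-type calcium channel subunit alpha-1C (Homo sapiens), read by FLIPR and calcium flux, tested at 3 uM (on this read-out higher numbers stand for a stronger effect at the one concentration tested and lower numbers for a weaker effect), and for compound 1 the entry reads "not determined" (no result reported); compound 2 `NC(=O)c1cccc(C(=O)N2CCC(N(C3CC3)S(=O)(=O)c3cccc(C(F)(F)F)c3)CC2)c1` was run in this assay as well, and for compound 2 the entry reads "not determined" (no result reported), so no result was reported for either. Among the compounds with values here, compound 3 `CS(=O)(=O)c1ccc(F)cc1C(=O)N1CCC(N(C2CC2)S(=O)(=O)c2cccc(C(F)(F)F)c2)CC1` is the only member with a number: in this assay compound 3 gives 34%, which makes it the sole reference point, with nothing to rank it against.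

Compound 4 `CN(C)c1cccc(C(=O)N2CCC(N(C3CC3)S(=O)(=O)c3cccc(C(F)(F)F)c3)CC2)c1` is not yet measured. It differs from compound 3 in a single place: 3-(dimethylamino)phenyl in place of 5-fluoro-2-(methylsulfonyl)phenyl on a carbonyl carbon. Within the data shown here, no pair of measured compounds shows how such a change moves the read-out, so the size and direction of the step cannot be taken from data. With only compound 3 as anchor, the most defensible expectation is a step that stays within the usual scatter, in no clear direction. On that basis compound 4 is estimated at 30% in this assay, with a range from 10% to 55%. This estimate means an expected step of a number 4 percentage points lower from compound 3 to compound 4 (within the scatter), which would not be distinguishable from the scatter of repeated measurements.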

Compound 4, a percentage reported as inhibition, at one concentration (the size of the read-out at that concentration, not a potency): 63%
Beside the measured number, compound 4's estimate is 33 percentage points below it; measured number outside the range, above it.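

In this assay, replacing 5-fluoro-2-(methylsulfonyl)phenyl with 3-(dimethylamino)phenyl on a carbonyl carbon gives a number 29 percentage points higher from compound 3 to compound 4 (beyond the scatter) and so shows that the read-out in this series responds to the aromatic group at this position, something a single number could not reveal. The change is not a single small edit, however: the group that leaves carries fluorine, sulfur and oxygen atoms, the group that enters carries a nitrogen atom, and the two differ in where their substituents sit, so the step belongs to the whole exchange and not to any one of these features. Nothing available here accounts for the size or direction of this step.

The compounds shown leave open whether the dimethylamino group itself matters, a question that a phenyl ring with a methoxy group or a diethylamino group in its place could help to answer. They also leave open whether the methylsulfonyl group or the fluorine of compound 3 accounts for more of the difference, and with one pair of compounds, no trend across this position can yet be drawn.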